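Swapping the amine on the pyridine-type core: a bulkier ring

The compounds below may be only part of what the source reports. "The series", "measured", "known", "first", "only" and "open" are said of these compounds alone.

Measured so far:
compound 1, `CCCCNc1nc(C(F)(F)F)ccc1CNC(=O)C(C)c1ccc(NS(C)(=O)=O)c(F)c1`: 9.1 nM
compound 2, `CC(C(=O)NCc1ccc(C(F)(F)F)nc1NCc1ccc(Cl)cc1)c1ccc(NS(C)(=O)=O)c(F)c1`: 65.7 nM
compound 3, `CC1CCCN1c1nc(C(F)(F)F)ccc1CNC(=O)[C@@H](C)c1ccc(NS(C)(=O)=O)c(F)c1`: 0.3 nM

In a functional assay on CHO-K1 cells for antagonist activity at transient receptor potential cation channel subfamily V member 1 (Homo sapiens), read by FLIPR (a higher number here means a weaker inhibitor, a lower number a stronger inhibitor), compound 2 gives the highest of the three numbers; compound 1 sits nearest, compound 3 furthest. Compound 4, `CC(C(=O)NCc1ccc(C(F)(F)F)nc1N1CCC(c2ccccc2)CC1)c1ccc(NS(C)(=O)=O)c(F)c1`, is not yet measured. It differs from compound 2 by 4-phenylpiperidin-1-yl in place of (4-chlorobenzyl)amino on an aromatic carbon. Going by the values given here, the one measured step that bears on this place is a 7.2-fold higher number from compound 1 to compound 2 (0.86 log units; beyond the scatter), where a large aromatic group weakened inhibition. Compounds 1 and 3 show that a cyclic amine at the same place gave a far lower number than an open chain. Compound 4 combines a cyclic amine with a large aromatic group, so a drop toward compound 1 is expected, a 4.4-fold lower number from compound 2 to compound 4 (0.64 log units; beyond the scatter). Compound 4 is estimated at 15 nM, between 2 nM and 100 nM.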

Compound 4, inhibition constant: 0.6 nM
Beside the measured number, compound 4's estimate is 25-fold (1.40 log units) above it; measured number below the stated range.
By their numbers in this assay, from the lowest: compounds 3 and 4 (each within the scatter of the next); then compound 1; then compound 2.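

In this assay, a phenyl ring at this place does not by itself cost inhibition: 4-phenylpiperidin-1-yl in place of (4-chlorobenzyl)amino gives a 110-fold lower number from compound 2 to compound 4 (2.04 log units; beyond the scatter), and in place of butylamino it gives a 15-fold lower number from compound 1 to compound 4 (1.18 log units; beyond the scatter), so this large group outdoes both open-chain amines. The change both closes a non-aromatic ring on the nitrogen and removes the hydrogen-bond donor, and these compounds cannot separate the two. No measurement at hand explains the gain.

As far as these compounds go, whether the phenyl ring adds anything remains open: unsubstituted piperidine or morpholine at this place would bear on that.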